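This account rests on a few compounds, and the source may have more. Where it says the series, first, only, none or still open, it means among the compounds named here.

Measured compounds:
compound 1 `CNC1=CC(=O)c2c(cnc(C)c2C)C1=O` gives 59100 nM
compound 2 `CNC1=CC(=O)c2cc(C)ncc2C1=O` gives 50600 nM

In a functional assay on RXF 486L cells (Homo sapiens) for cytotoxicity, read by propidium iodide staining, with a stated time of 4 days (a higher number here means a weaker inhibitor, a lower number a stronger inhibitor), compound 1 gives 59100 nM, and compound 2 gives 50600 nM. For the measured compounds named here, the single step recorded so far, a 1.2-fold lower number from compound 1 to compound 2 (0.07 log units; within the scatter), is a change of hydrogen in place of methyl on an aromatic carbon and stays within the scatter, so the two values cannot be ordered. Compound 2 is therefore not distinguished from compound 1 on the numbers in hand; it simply carries the lower of the two entries, and the difference between them means nothing.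

Compound 3 `Cc1cc2c(cn1)C(=O)C(NCl)=CC2=O` is the unmeasured member. The change from compound 2 to compound 3 is chloro in place of methyl on an amine nitrogen. Going by the values given here, no measured step touches the substituent on the amine nitrogen: the only recorded step concerns an aromatic carbon and is itself within the scatter, so it offers no direction for this change. The working expectation for this assay is accordingly no step beyond the scatter, with a broad band of uncertainty. Compound 3 is estimated at 50000 nM with a range of 12000 nM to 200000 nM, meaning an expected step of a 1.0-fold lower number from compound 2 to compound 3 (0.01 log units; within the scatter).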

Compound 3, half-maximal inhibitory concentration: 17900 nM
Compound 3: middle estimate off by 2.8-fold (0.45 log units), on the high side; the range from low to high includes it.
By their numbers in this assay, from the lowest: compound 3; then compounds 2 and 1 (each within the scatter of the next).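

In this assay, for the compounds shown here, the substituent on the amine nitrogen gives the first single change that reads beyond the scatter: chloro in place of methyl at this place is a 2.8-fold lower number from compound 2 to compound 3 (0.45 log units; beyond the scatter), a modest step. The only earlier step, a 1.2-fold lower number from compound 1 to compound 2 (0.07 log units; within the scatter), sits on an aromatic carbon and stays within the scatter, so the amine nitrogen is so far the one position shown to register in this read-out, on the strength of a single pair. Nothing in hand speaks to the reason for the step.

Open is whether the step belongs to chloro itself or to the loss of methyl, as only these two groups are shown on the amine nitrogen; a free amine, bromo or a longer chain such as ethyl at the same place would separate the two readings. Also open, as far as these compounds go, is whether the same exchange gives a step of similar size on the core of compound 1, which carries the additional methyl on an aromatic carbon.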